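Fluoro for Trifluoromethyl on the Aryl Group

A few compounds are considered here, and "the series" means these few. Any claim that something is new, unique, unknown or untested is made for them only; others in the source may bear on it.

Compound 1 `COC(=O)N[C@H](C(=O)N1CCC[C@H]1C(=O)Nc1ccc([C@H]2CC[C@H](c3ccc(NC(=O)[C@@H]4CCCN4C(=O)[C@@H](NC(=O)OC)C(C)C)cc3)N2c2ccc(C(F)(F)F)cc2)cc1)C(C)C` is the reference point here. In an ADME assay (liver) for metabolic stability, with Liver microsome (Rattus norvegicus) as the target, using microsomes, with a stated time of 30 min (on this read-out lower numbers stand for a less stable compound and higher numbers for a more stable compound), compound 1 gives 58%, the highest of the three numbers at hand. Compound 2 `COC(=O)N[C@H](C(=O)N1CCC[C@H]1C(=O)Nc1ccc([C@H]2CC[C@H](c3ccc(NC(=O)[C@@H]4CCCN4C(=O)[C@@H](NC(=O)OC)[C@@H](C)OC)cc3)N2c2ccc(F)cc2)cc1)[C@@H](C)OC` gives 46% and compound 3 `COC(=O)N[C@H](C(=O)N1CCC[C@H]1C(=O)Nc1ccc([C@@H]2CC[C@@H](c3ccc(NC(=O)[C@@H]4CCCN4C(=O)[C@@H](NC(=O)OC)[C@H]4CCOC4)cc3)N2c2ccc(F)cc2)cc1)[C@H]1CCOC1` gives 42%; both gaps to compound 1 lie beyond the scatter. Compound 4 `COC(=O)N[C@H](C(=O)N1CCC[C@H]1C(=O)Nc1ccc([C@H]2CC[C@H](c3ccc(NC(=O)[C@@H]4CCCN4C(=O)[C@@H](NC(=O)OC)C(C)C)cc3)N2c2ccc(F)cc2)cc1)C(C)C` differs from compound 1 by fluoro in place of trifluoromethyl on an aromatic carbon. For the measured compounds named here, no step between measured compounds covers this single change, so the direction rests on the structural change and the two lower readings of compound 2 and compound 3. Compound 4 is expected to fall a little lower, a step of a number 8 percentage points lower from compound 1 to compound 4 (within the scatter) in this assay. For compound 4 the estimate is 50%, with a range from 36% to 64%.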

Compound 4, percent of the compound remaining: 38%
Compound 4: middle estimate off by 12 percentage points, on the high side, within the range that was stated.
By their numbers in this assay, from the lowest: compounds 4, 3 and 2 (each within the scatter of the next); then compound 1.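

In this assay, for the compounds shown here, fluoro in place of trifluoromethyl on an aromatic carbon, para to a large group, gives a number 20 percentage points lower from compound 1 to compound 4 (beyond the scatter) as the only change between the two structures. Going by these compounds alone, this is the first reading of a single change at this position, and it shows that the group held there matters on its own, apart from the other parts of the molecule. Nothing measured here explains the step. Going by these compounds, whether chloro, a nitrile or a methoxy group on the same carbon would read closer to compound 1 or to compound 4 remains open. So does whether the step would hold with other side chains on the shared core.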